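The compounds below may be only part of what the source reports. "The series", "measured", "known", "first", "only" and "open" are said of these compounds alone.

Measured in an ADME assay on HCT-116 cells (Homo sapiens) for cytotoxicity, read by CellTiter-Glo, with a stated time of 72 h; a lower number here means a stronger inhibitor, a higher number a weaker inhibitor:
- compound 1 `Cc1cc(C)c(S(=O)(=O)N2CCC(N3CCC(c4ccccc4)CC3)CC2)c(C)c1`: > 5000 nM (a limit)
- compound 2 `Cc1cc(C)c(S(=O)(=O)N2CCC(N3CCC(CCC#N)CC3)CC2)c(C)c1`: > 5000 nM (a limit)

Compound 2 has no numerical value in this assay. Compound 2 is known only as a limit, > 5000 nM. The evidence so far is the limit of > 5000 nM in this assay, at which 2 of the 2 values shown sit.

Compound 3 `Cc1cc(C)c(S(=O)(=O)N2CCC(N3CCC(Cc4ccc(F)cc4)CC3)CC2)c(C)c1` changes compound 2 as follows: 4-fluorophenyl in place of cyanomethyl on a saturated chain carbon bound to a saturated ring carbon. In words, 4-fluorophenyl takes the place of cyanomethyl on a saturated chain carbon bound to a saturated ring carbon, which, cut one bond further out, reads 2-cyanoethyl to 4-fluorobenzyl.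

For the measured compounds named here, only one measured step bears on this change: a step that the two limits leave unreadable from compound 1 to compound 2. It has no readable size, so it offers no measured effect to carry over. Compound 1 and compound 2 both carry different groups at this part of the shared core, yet neither gives a number, so the expectation rests on (the limit of > 5000 nM in this assay, at which 2 of the 2 values shown sit).

No step beyond the scatter and no direction is expected in this assay, and the expected step, a step that the limit leaves unreadable from compound 2 to compound 3, is only an estimate. For compound 3 the estimated value is 6000 nM, with an expected range of 2000 nM to 15000 nM.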

Compound 3, half-maximal inhibitory concentration: > 5000 nM
Compound 3: a limit, no number (the forecaster's own chance of this, stated with the estimate: 75%); the middle value lies beyond the limit too.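

In this assay compound 3 gives > 5000 nM, a limit and not a number. The steps from compound 2 to compound 3 and from compound 1 to compound 3 therefore cannot be read. Left open: whether any group at this place on the shared core gives a numerical value in this assay, and how phenyl, 2-cyanoethyl and 4-fluorobenzyl compare.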